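Taking the phenethylcarbonyl group off compound 2

A few compounds are considered here, and "the series" means these few. Any claim that something is new, unique, unknown or untested is made for them only; others in the source may bear on it.

In a toxicity assay on KB cells (Homo sapiens) for cytotoxicity, read by fluorescence, with a stated time of 3 days (on this read-out higher numbers stand for an effect only at larger amounts of compound and lower numbers for an effect already at smaller amounts), compound 2 (`CCCCOC(=O)CNC(=O)[C@H](CSc1ccc([N+](=O)[O-])cc1[N+](=O)[O-])NC(=O)CC[C@H](NC(=O)CCc1ccccc1)C(=O)OCCCC`) reads > 300 uM as a limit of the assay, not a number. Compound 1 (`CCCCOC(=O)CNC(=O)[C@H](CSc1ccc([N+](=O)[O-])cc1[N+](=O)[O-])NC(=O)CC[C@H](NC(=O)COc1ccccc1)C(=O)OCCCC`) reads > 300 uM as a limit too. Among the measured compounds shown here, the series so far amounts to the limit of > 300 uM in this assay, at which 2 of the 2 values shown sit, and nothing finer.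

Compound 3 (`CCCCOC(=O)CNC(=O)[C@H](CSc1ccc([N+](=O)[O-])cc1[N+](=O)[O-])NC(=O)CC[C@H](N)C(=O)OCCCC`) differs from compound 2 by hydrogen in place of phenethylcarbonyl on an amine nitrogen as hydrogen in place of phenethylcarbonyl on an amine nitrogen. For the measured compounds named here, the only measured step (a step that the two limits leave unreadable from compound 1 to compound 2) offers no size to carry over. Compound 2 sits at > 300 uM as a limit, so any number read for compound 3 would lie lower. The expected change is an at least 2.5-fold lower number from compound 2 to compound 3 (0.39 log units; beyond the scatter) and this estimate is loosely held. For compound 3 the estimated value is 120 uM within an expected range from 25 uM to 500 uM and a further limit remains quite possible.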

Compound 3, concentration for half-maximal effect: 107 uM
The estimate for compound 3 lay 1.1-fold (0.05 log units) above the measured number; the measured number falls inside the stated range.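

In this assay, among the compounds shown here, the amine nitrogen is the first place where a change gives a readable number. Hydrogen in place of phenethylcarbonyl gives an at least 2.8-fold lower number from compound 2 to compound 3 (0.44 log units; beyond the scatter), and hydrogen in place of (phenoxymethyl)carbonyl at the same nitrogen gives an at least 2.8-fold lower number from compound 1 to compound 3 (0.44 log units; beyond the scatter). The two acylated compounds could not show this on their own, and both new sizes are lower bounds only, as each starts from a limit rather than a number.

As far as these compounds go, it remains open whether a smaller group on this nitrogen, such as acetyl or methyl, would give a number or stay at the limit. Also open, from the compounds shown here alone, is whether the reading of compound 3 would hold with a carboxylic acid in place of a butyl ester.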